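The compounds below may be only part of what the source reports. "The series", "measured", "known", "first", "only" and "open" are said of these compounds alone.

Working notes on the series.

The three measured compounds share one core and differ only in the group on the nitrogen. In an ADME assay on Li23 cells (Homo sapiens) for cytotoxicity, read by WST assay (on this read-out lower numbers stand for higher toxicity in this test and higher numbers for lower toxicity in this test), compound 1 `CN(C(=O)C1CCCCC1)c1ccc(C(O)(C(F)(F)F)C(F)(F)F)cc1` gives 20000 nM. Compound 2 `CN(C(=O)c1cccs1)c1ccc(C(O)(C(F)(F)F)C(F)(F)F)cc1` gives 33000 nM in this assay, and compound 3 `CN(c1ccc(C(O)(C(F)(F)F)C(F)(F)F)cc1)S(=O)(=O)c1ccccc1` gives 16000 nM in this assay. The steps among them are a 1.7-fold higher number from compound 1 to compound 2 (0.22 log units; within the scatter), a 1.3-fold lower number from compound 1 to compound 3 (0.10 log units; within the scatter) and a 2.1-fold lower number from compound 2 to compound 3 (0.31 log units; beyond the scatter). Compound 3 thus holds the lowest of the three numbers, but its gap to compound 1 is within the scatter and only its gap to compound 2 goes beyond it, and that modestly.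

Compound 4 `CN(c1ccc(C(O)(C(F)(F)F)C(F)(F)F)cc1)S(=O)(=O)c1cccc(F)c1` differs from compound 3 by fluoro in place of hydrogen on an aromatic carbon. For the measured compounds named here, none of the measured steps touches a substituent within the phenylsulfonyl group; each of them exchanges the whole group on the nitrogen, and even those larger exchanges move the numbers within or only just beyond the scatter. Going by the values given here, no measured step therefore bears directly on the change from compound 3 to compound 4, and the narrow spread of the three values gives no ground to expect a step beyond the scatter in this assay in either direction. Compound 4 is accordingly expected to show no change at the digits printed from compound 3 to compound 4 (within the scatter), with an estimated value of 16000 nM and a range from 7000 nM to 35000 nM.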

Compound 4, half-maximal cytotoxic concentration: 19000 nM
Compound 4: the middle estimate sits 1.2-fold (0.07 log units) below what was measured, within the range that was stated.
By their numbers in this assay, from the lowest: compounds 3, 4, 1 and 2 (each within the scatter of the next, the first and the last beyond it).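

In this assay, for the compounds shown here, fluoro in place of hydrogen on an aromatic carbon, meta to a large group, gives a 1.2-fold higher number from compound 3 to compound 4 (0.07 log units; within the scatter), and this is the first step that alters a substituent within the phenylsulfonyl group instead of exchanging the whole group on the nitrogen. The step lies within the scatter, so the read-out does not separate 3-fluorophenyl from phenyl on the sulfonyl, and at this place on the ring a single fluoro leaves the cytotoxicity reading unresolved from that of the unsubstituted phenyl. No measurement at hand speaks to the reason for this outcome.

The compounds shown leave open whether a group with more heavy atoms at this same place, such as an amine, a carboxylic acid, a methoxy group or a longer alkyl chain, would move the number beyond the scatter. They also leave open whether fluoro elsewhere on the same ring, or chloro at this place, would read the same way in this cell assay.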